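The compounds below may be only part of what the source reports. "The series", "measured", "known", "first", "only" and "open" are said of these compounds alone.

Compound 1 `CCc1c(F)c(N)c2c(=O)cc(-c3ccc(N)c(F)c3)oc2c1F` gives 130 nM in a functional assay on MCF7 cells (Homo sapiens) for cytotoxicity, read by neutral red uptake, with a stated time of 3 days; on this read-out higher numbers stand for weaker inhibition and lower numbers for stronger inhibition. Compound 3 `CN(C)c1c(F)c(N)c2c(=O)cc(-c3ccc(N)c(F)c3)oc2c1F` gives 39 nM. Compound 2 `CCCCCCc1c(F)c(N)c2c(=O)cc(-c3ccc(N)c(F)c3)oc2c1F` reaches only a limit of the assay, > 10000 nM.

Among the two plain numbers, compound 3 stands lowest, and its nearest neighbour is compound 1, separated by a 3.3-fold lower number from compound 1 to compound 3 (0.52 log units; beyond the scatter). Compound 4 `CCOC(=O)c1c(F)c(N)c2c(=O)cc(-c3ccc(N)c(F)c3)oc2c1F` differs from compound 3 by ethoxycarbonyl in place of dimethylamino on an aromatic carbon. For the measured compounds named here, two measured steps touch the same aromatic carbon: a 3.3-fold lower number from compound 1 to compound 3 (0.52 log units; beyond the scatter) and an at least 250-fold lower number from compound 2 to compound 3 (2.40 log units; beyond the scatter), the latter resting on (the limit of > 10000 nM in this assay, at which 1 of the 3 values shown sits). Neither step tests an ethoxycarbonyl, so the direction is uncertain; the change is expected to be upward and modest, a 7.7-fold higher number from compound 3 to compound 4 (0.89 log units; beyond the scatter). Compound 4 is therefore estimated at 300 nM, somewhere between 60 nM and 3000 nM in this assay.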

Compound 4, half-maximal inhibitory concentration: 1400 nM
Compound 4: middle estimate off by 4.7-fold (0.67 log units), on the low side; low and high end bracket the measured number.
By their numbers in this assay, from the lowest: compound 3; then compound 1; then compound 4. At a limit, above all of these: compound 2.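

At this aromatic carbon in this assay, ethoxycarbonyl gives up much of what the two small groups achieve: a 36-fold higher number from compound 3 to compound 4 (1.56 log units; beyond the scatter) and an 11-fold higher number from compound 1 to compound 4 (1.03 log units; beyond the scatter). Even so, it does not fall as far as hexyl, with an at least 7.1-fold lower number from compound 2 to compound 4 (0.85 log units; beyond the scatter). That last step is only a bound, since compound 2 stands at a limit and not at a number: the limit of > 10000 nM in this assay, at which 1 of the 4 values shown sits.

From the compounds shown here alone, whether the loss belongs to the ester itself or simply to a longer group stays open. A carboxylic acid, an amide or a methoxy group at this carbon would help to separate the two.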